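Replacing the cyclohexyl group of compound 3

The compounds below may be only part of what the source reports. "The series", "measured", "known", "first", "only" and "open" are said of these compounds alone.

Measured in a physicochemical assay for lipophilicity, read by HPLC, measured as chromatographic lipophilicity, at pH 7.4; a lower number here means a more polar compound, a higher number a more lipophilic compound:
compound 1 `CC(=O)N1CCC(C(=O)N2N=CCC2c2ccccc2)CC1` gives 2.5
compound 2 `O=C(C1CCN(C(=O)C(F)(F)F)CC1)N1N=CCC1c1ccccc1` gives 4.9
compound 3 `O=C(C1CCCCC1)N1CCC(C(=O)N2N=CCC2c2ccccc2)CC1` gives 5.4

Compound 3 stands highest of the three, and its gaps to compound 2 and compound 1 both lie beyond the scatter. The next compound, compound 4 `O=C(c1c[nH]nn1)N1CCC(C(=O)N2N=CCC2c2ccccc2)CC1`, has 1H-1,2,3-triazol-4-yl in place of cyclohexyl on a carbonyl carbon while the rest of the molecule stays the same. Three measured steps changed this same group. Cyclohexyl in place of methyl gave the large step of a number 2.90 log units higher from compound 1 to compound 3 (beyond the scatter) and trifluoromethyl in place of methyl gave the large step of a number 2.40 log units higher from compound 1 to compound 2 (beyond the scatter) while cyclohexyl in place of trifluoromethyl gave the modest step of a number 0.50 log units higher from compound 2 to compound 3 (beyond the scatter) as its result. Among the compounds with values here, no measured compound carries the entering ring, so the size remains a judgement. Reading the step of a number 2.90 log units higher from compound 1 to compound 3 (beyond the scatter) in reverse as the closest guide, a large fall is expected in this assay and the estimated change is a number 2.80 log units lower from compound 3 to compound 4 (beyond the scatter) in all. Compound 4 is estimated at 2.6 with an expected range of 1.9 to 3.3 for its measurement.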

Compound 4, distribution coefficient: 2
The estimate for compound 4 lay 0.60 log units above the measured number; measured number inside the range.
By their numbers in this assay, from the lowest: compound 4; then compound 1; then compound 2; then compound 3.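

Within the data shown here, at this place, on a carbonyl carbon, the 1H-1,2,3-triazol-4-yl ring gives the lowest number so far in this assay, with a number 3.40 log units lower from compound 3 to compound 4 (beyond the scatter) and a number 2.90 log units lower from compound 2 to compound 4 (beyond the scatter). Until now, both replacements of methyl had raised the number, whereas this ring lowers it, with a number 0.50 log units lower from compound 1 to compound 4 (beyond the scatter), so changes at this one position can move the read-out in either direction from methyl. Nothing shown here explains why the ring has this result.

The compounds shown leave open whether the fall follows from the ring's nitrogen atoms and its hydrogen-bond donor or from the aromatic ring itself. A phenyl ring on the same carbonyl carbon would help separate those two, and a triazole with a methyl group in place of its ring hydrogen would show how much that hydrogen matters.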